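Working notes: amide nitrogen substituent, step to compound 4

The source may report more compounds than this note shows. Statements on the series, on what has been measured and on what is new or still open speak of the compounds shown alone.

Measured so far in a functional assay on HL-60 cells (Homo sapiens), with a stated time of 2 days; a higher number here means a weaker inhibitor, a lower number a stronger inhibitor:
compound 1 `CCCCCCNC(=O)c1[nH]cnc1C(=O)Nc1ccc(Cl)c(Cl)c1` gives 14600 nM
compound 2 `C[C@@H](NC(=O)c1[nH]cnc1C(=O)Nc1ccc(Cl)c(Cl)c1)c1ccccc1` gives 8800 nM
compound 3 `C[C@H](NC(=O)c1[nH]cnc1C(=O)Nc1ccc(Cl)c(Cl)c1)c1ccccc1` gives 9200 nM

Compound 3 stands second highest of the three numbers; compound 2 is nearest, compound 1 furthest, and both lie within the scatter of compound 3. The step of a 1.0-fold higher number from compound 2 to compound 3 (0.02 log units; within the scatter) rests on (the fact that compounds 2 and 3 differ only in the configuration as drawn), so the configuration at that carbon makes no measurable difference. The two steps that change the group on the amide-type nitrogen, a 1.7-fold lower number from compound 1 to compound 2 (0.22 log units; within the scatter) and a 1.6-fold lower number from compound 1 to compound 3 (0.20 log units; within the scatter), are likewise within the scatter, so exchanging hexyl for 1-phenylethyl moved nothing beyond noise.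

Compound 4 `CC(C)(C)OC(=O)CNC(=O)c1[nH]cnc1C(=O)Nc1ccc(Cl)c(Cl)c1` differs from compound 3 by (tert-butoxycarbonyl)methyl in place of 1-phenylethyl on an amide-type nitrogen. Among the measured compounds shown here, the substituent now entering is neither a chain nor a ring of the kind tried before, but every change at this position so far has stayed within the scatter, and the same is expected here in this assay, an expected step of a 1.2-fold higher number from compound 3 to compound 4 (0.08 log units; within the scatter). Compound 4 is therefore estimated at 11000 nM, with a range from 4000 nM to 30000 nM.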

Compound 4, half-maximal inhibitory concentration: 49800 nM
Estimate against measurement, compound 4: 4.5-fold (0.66 log units) below, outside the stated range (above it).
By their numbers in this assay, from the lowest: compounds 2, 3 and 1 (each within the scatter of the next); then compound 4.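

In this assay, among the compounds shown here, this position on the amide-type nitrogen is no longer flat: (tert-butoxycarbonyl)methyl in place of 1-phenylethyl gives a 5.4-fold higher number from compound 3 to compound 4 (0.73 log units; beyond the scatter) and also a 5.7-fold higher number from compound 2 to compound 4 (0.75 log units; beyond the scatter) in the first changes here beyond the scatter. Measured against the hexyl compound, the same change reads as a 3.4-fold higher number from compound 1 to compound 4 (0.53 log units; beyond the scatter) for tert-butoxycarbonyl in place of pentyl on a saturated chain carbon bound to an amide-type nitrogen, which makes compound 4 the weakest of the four and limits the earlier flat reading to hexyl and 1-phenylethyl. The loss does not rest on one drawn configuration, since the steps from both 1-phenylethyl compounds lie beyond the scatter: the fact that compounds 2 and 3 differ only in the configuration as drawn.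

With one compound of this kind, the change cannot be assigned to the carbonyl, the tert-butyl part or the absence of a ring. Going by these compounds, whether a free carboxylic acid, a methyl ester or a primary amide on the same methylene would stay this weak remains open.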